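The source may hold more compounds than are shown below. What is called first, only, known or untested is meant among the compounds shown, and "the series" means these compounds.

In an assay on isolated protein for inhibition of Flap endonuclease 1 (Homo sapiens) (on this read-out lower numbers stand for stronger inhibition and higher numbers for weaker inhibition), compound 1 `CNC(=O)c1nc(-c2cccs2)[nH]c(=O)c1O` gives 12000 nM, compound 2 `O=C(NCCO)c1nc(-c2cccs2)[nH]c(=O)c1O` gives 4000 nM, and compound 3 `CC(C)CCNC(=O)c1nc(-c2cccs2)[nH]c(=O)c1O` gives 3500 nM. Going from compound 1 to compound 2 the number falls a 3.0-fold lower number from compound 1 to compound 2 (0.48 log units; beyond the scatter), and from compound 1 to compound 3 it falls a 3.4-fold lower number from compound 1 to compound 3 (0.54 log units; beyond the scatter), while from compound 2 to compound 3 the change is a 1.1-fold lower number from compound 2 to compound 3 (0.06 log units; within the scatter). Compound 3 thus has the lowest of the three numbers, though it cannot be separated from compound 2. Compound 4 `CC(C)CCNC(=O)c1nc(C2CCN(C)CC2)[nH]c(=O)c1O` differs from compound 3 by 1-methylpiperidin-4-yl in place of thiophen-2-yl on an aromatic carbon. Within the data shown here, all three measured steps concern the amide side, so no measured step bears on this change. Compound 4 is therefore estimated, with wide uncertainty, at 8000 nM (range 2000 nM to 30000 nM), which would mean a step of a 2.3-fold higher number from compound 3 to compound 4 (0.36 log units; beyond the scatter) in this assay.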

Compound 4, half-maximal inhibitory concentration: > 100000 nM
Compound 4 gave a limit, no number; the forecaster's own chance of this, stated with the estimate: 15%; middle value at least 12-fold (1.09 log units) from the limit.
By their numbers in this assay, from the lowest: compounds 3 and 2 (each within the scatter of the next); then compound 1. At a limit, above all of these: compound 4.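

Replacing thiophen-2-yl with 1-methylpiperidin-4-yl on the aromatic carbon between two ring nitrogen atoms gives an at least 28-fold higher number from compound 3 to compound 4 (1.45 log units; beyond the scatter), the first step shown at this position. It is a large step, whereas the steps on the amide side are modest or within the scatter, so this position matters strongly to the read-out. Compound 4 gives a limit, not a number: the limit of > 100000 nM in this assay, at which 1 of the 4 values shown sits.

With one replacement shown, it stays open whether the loss follows from the non-aromatic ring or from its nitrogen. Cyclohexyl, phenyl or unmethylated piperidin-4-yl here could separate these.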